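The compounds below may be only part of what the source reports. "The series", "measured", "known", "first", "only" and "open" are said of these compounds alone.

Three related compounds have been tested in a functional assay on SMMC-7721 cells (Homo sapiens) for cytotoxicity, read by MTT assay, with a stated time of 24 h; on this read-out lower numbers stand for stronger inhibition and higher numbers for weaker inhibition. Compound 1 `O=C1/C(=C/c2cccc([N+](=O)[O-])c2)CN(S(=O)(=O)c2ccc(F)cc2)C/C1=C\c1ccccc1F` gives 7820 nM in this assay. Compound 2 `N#Cc1ccc(/C=C2\CN(S(=O)(=O)c3ccc(F)cc3)C/C(=C\c3ccccc3F)C2=O)cc1` differs from compound 1 by 4-cyanophenyl in place of 3-nitrophenyl on a double-bonded chain carbon bound to a double-bonded ring carbon, and in this assay compound 2 gives 10300 nM, a step of a 1.3-fold higher number from compound 1 to compound 2 (0.12 log units; within the scatter). Compound 3 `COc1cc(/C=C2\CN(S(=O)(=O)c3ccc(F)cc3)C/C(=C\c3cccc([N+](=O)[O-])c3)C2=O)cc(OC)c1OC` stands on a different core: its core differs from that of compound 1 by 3,4,5-trimethoxyphenyl in place of 2-fluorophenyl on a double-bonded chain carbon bound to a double-bonded ring carbon. In this assay compound 3 gives 4900 nM, which is a 1.6-fold lower number from compound 1 to compound 3 (0.20 log units; within the scatter).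

Compound 4 `COc1cc(/C=C2\CN(S(=O)(=O)c3ccc(F)cc3)C/C(=C\c3ccc(C#N)cc3)C2=O)cc(OC)c1OC` has not yet been measured. It differs from compound 3 by 4-cyanophenyl in place of 3-nitrophenyl on a double-bonded chain carbon bound to a double-bonded ring carbon. This is the same change that separates compound 1 from compound 2, so among these compounds it occurs twice. A step of similar size is expected here, a 1.3-fold higher number from compound 3 to compound 4 (0.12 log units; within the scatter), since the one earlier case of this change gave a 1.3-fold higher number from compound 1 to compound 2 (0.12 log units; within the scatter). That expectation rests on a single pair and on compound 3 sitting at 4900 nM, so it carries real uncertainty. Compound 4 is therefore estimated to give 6500 nM in this assay, with a likely range from 3500 nM to 12000 nM.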

Compound 4, half-maximal inhibitory concentration: 4120 nM
For compound 4 the middle estimate is 1.6-fold (0.20 log units) above the measured one; low and high end bracket the measured number.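

In this assay, among these compounds, 4-cyanophenyl in place of 3-nitrophenyl gives a 1.2-fold lower number from compound 3 to compound 4 (0.08 log units; within the scatter), so on this second core the change again stays small, and its two cases agree: the same change on two cores in this assay, a 1.3-fold higher number (0.12 log units; within the scatter) from compound 1 to compound 2 and a 1.2-fold lower number (0.08 log units; within the scatter) from compound 3 to compound 4, 1.6-fold (0.19 log units) apart, within the scatter of two such steps The other change, 3,4,5-trimethoxyphenyl in place of 2-fluorophenyl, gives a 2.5-fold lower number from compound 2 to compound 4 (0.40 log units; beyond the scatter), which passes the scatter although its earlier case did not, yet the two cases still cannot be told apart: the same change on two cores in this assay, a 1.6-fold lower number (0.20 log units; within the scatter) from compound 1 to compound 3 and a 2.5-fold lower number (0.40 log units; beyond the scatter) from compound 2 to compound 4, 1.6-fold (0.19 log units) apart, within the scatter of two such steps Both changes therefore carry over between these two cores without a detectable difference, but each rests on only two pairs of compounds, so this does not show that they would carry over to any other core, and it does not explain why they behave this way.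

The compounds shown leave open whether these steps would stay as small with an amine, a carboxylic acid or a longer chain on a double-bonded chain carbon bound to a double-bonded ring carbon. They also leave open whether the same picture would hold in other cell lines or at other exposure times.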